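One Swap, Made Twice on a Shared Core

The compounds below may be only part of what the source reports. "The series", "measured", "known", "first", "only" and "open" are said of these compounds alone.

Four related compounds are compared in a functional assay on HepG2 cells (Homo sapiens) for antiproliferative activity, read by MTT assay, with a stated time of 48 h; on this read-out lower numbers stand for stronger inhibition and higher numbers for weaker inhibition. Compound 1 `COc1ccc(-c2c(Nc3ccc(NC(C)=O)cc3)c3ccc(OC)cc3oc2=O)cc1` gives > 100000 nM in this assay, which is a limit of the assay rather than a number. Compound 2 `COc1ccc(-c2c(Nc3cccc(C(F)(F)F)c3)c3ccc(OC)cc3oc2=O)cc1` differs from compound 1 by 3-(trifluoromethyl)phenyl in place of 4-acetamidophenyl on a nitrogen on an aromatic ring, and in this assay compound 2 gives 57300 nM. That change made an at least 1.7-fold lower number from compound 1 to compound 2 (0.24 log units; that floor lies within the scatter). Compound 3 `COc1ccc(-c2c(Nc3ccc(NC(C)=O)cc3)c3ccc(O)cc3oc2=O)cc1` differs from compound 1 in its core by hydrogen in place of methyl on an oxygen on an aromatic ring. In this assay compound 3 gives > 100000 nM, again a limit and not a number. Two of the three measured values sit at the limit of > 100000 nM in this assay, at which 2 of the 3 values shown sit, so the step from compound 1 to compound 3 is a step that the two limits leave unreadable from compound 1 to compound 3.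

Compound 4 `COc1ccc(-c2c(Nc3cccc(C(F)(F)F)c3)c3ccc(O)cc3oc2=O)cc1` has not yet been measured. It differs from compound 3 by 3-(trifluoromethyl)phenyl in place of 4-acetamidophenyl on a nitrogen on an aromatic ring, the same change that turns compound 1 into compound 2, made at the same place. For compound 4 the expected step is an at least 1.4-fold lower number from compound 3 to compound 4 (0.15 log units; that floor lies within the scatter). The estimate for compound 4 is 70000 nM, with a range from 30000 nM to 200000 nM. This expectation rests on compound 2, which gives 57300 nM after the same change. The starting point, compound 3, offers only a limit of the assay.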

Compound 4, half-maximal inhibitory concentration: 53600 nM
Estimate against measurement, compound 4: 1.3-fold (0.12 log units) above; the measured number falls inside the stated range.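

In this assay, the swap of 4-acetamidophenyl for 3-(trifluoromethyl)phenyl, carried from the core of compound 1 to the core of compound 3, gives an at least 1.8-fold lower number from compound 3 to compound 4 (0.27 log units; that floor lies within the scatter). Compound 1 and compound 3 each stand at a limit of the assay and not at a number, so the true size of both swap steps stays hidden, and the step between those two compounds cannot be read: the limit of > 100000 nM in this assay, at which 2 of the 4 values shown sit. The two floors point the same way, but neither clears the usual scatter, so this shows no firm gain on either core and no proof that the change is the same size on both: the same change on two cores in this assay, an at least 1.7-fold lower number (0.24 log units; that floor lies within the scatter) from compound 1 to compound 2 and an at least 1.8-fold lower number (0.27 log units; that floor lies within the scatter) from compound 3 to compound 4; the limit leaves it open whether they differ.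

Going by these compounds, the hydrogen-for-methyl change on the oxygen can be read only with 3-(trifluoromethyl)phenyl in place, where it gives a 1.1-fold lower number from compound 2 to compound 4 (0.03 log units; within the scatter), so its effect with 4-acetamidophenyl stays open. Also open, on these data alone, is whether a carboxylic acid or an amine in place of these two groups would behave alike on both cores.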